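From pyrrolidin-1-yl to dipropylamino on a side chain

A few compounds are considered here, and "the series" means these few. Any claim that something is new, unique, unknown or untested is made for them only; others in the source may bear on it.

Of the compounds shown here, three sharing a core have so far been measured in a functional assay on MCF7 cells (Homo sapiens) for antiproliferative activity (on this read-out higher numbers stand for weaker inhibition and lower numbers for stronger inhibition), to date. Compound 1 (`CC(=O)Oc1ccc(C(=O)Nc2cc3ccc(OCCC4CCCCN4)c(C)c3oc2=O)cc1CC=C(C)C`) gives 710 nM here, compound 2 (`CC(=O)Oc1ccc(C(=O)Nc2cc3ccc(OCC4CCCNC4)c(C)c3oc2=O)cc1CC=C(C)C`) gives 820 nM here, and compound 3 (`CC(C)=CCc1cc(C(=O)Nc2cc3ccc(OCCCN4CCCC4)c(C)c3oc2=O)ccc1O`) gives 990 nM on the same read-out. All three numbers lie within the usual scatter of one another, so compound 3 cannot be told apart from either of the others.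

Compound 4 (`CCCN(CCC)CCCOc1ccc2cc(NC(=O)c3ccc(O)c(CC=C(C)C)c3)c(=O)oc2c1C`) has not been measured. It differs from compound 3 in one place (dipropylamino in place of pyrrolidin-1-yl on a saturated chain carbon, three bonds along the chain from an oxygen on an aromatic ring), where dipropylamino stands in place of pyrrolidin-1-yl on a saturated chain carbon, three bonds along the chain from an oxygen on an aromatic ring.

Going by the values given here, only one measured step offers any guidance. This is a 1.2-fold higher number from compound 1 to compound 2 (0.06 log units; within the scatter) and it also alters a nitrogen-bearing group on the chain. It is an imperfect guide, since it is a different swap and compounds 1 and 2 also differ from compound 3 elsewhere. No direct measurement yet shows what dipropylamino does here.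

Going by a 1.2-fold higher number from compound 1 to compound 2 (0.06 log units; within the scatter) as a small step, and starting from compound 3 at 990 nM as the anchor, no step beyond the scatter is expected in this assay for this change. The estimated change is a 1.0-fold higher number from compound 3 to compound 4 (0.00 log units; within the scatter) in this expectation. For compound 4 the expected value is 1000 nM as the estimate, with an expected range from 450 nM to 2200 nM as its limits.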

Compound 4, half-maximal inhibitory concentration: > 50000 nM
Compound 4 ended at the assay's limit; the forecaster's own chance of this, stated with the estimate: 3%; at least 50-fold (1.69 log units) between middle value and limit.
By their numbers in this assay, from the lowest: compounds 1, 2 and 3 (each within the scatter of the next). At a limit, above all of these: compound 4.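

In this assay, the change from pyrrolidin-1-yl to dipropylamino on this side chain produces an at least 50-fold higher number from compound 3 to compound 4 (1.70 log units; beyond the scatter), so the group at the end of the chain can matter a great deal. Going by these compounds alone, the only earlier step, a 1.2-fold higher number from compound 1 to compound 2 (0.06 log units; within the scatter), also altered a nitrogen-bearing group on the chain but stayed small, and it gave no sign that a single swap here could cost this much activity. The result for compound 4 is a limit of the assay and not a number: the limit of > 50000 nM in this assay, at which 1 of the 4 values shown sits.

The compounds shown cannot tell whether the loss comes with opening the ring or with the larger count of carbon atoms in dipropylamino, since the two change together in this one step. On these data alone, a smaller open-chain amine such as dimethylamino, or a larger ring amine such as piperidin-1-yl, in the same place on the chain would pull these two differences apart, and how either would behave in this assay remains open.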